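Losing the chloro group: what compound 4 may show

A few compounds are considered here, and "the series" means these few. Any claim that something is new, unique, unknown or untested is made for them only; others in the source may bear on it.

The shared core is seen in compound 1 `O=C1c2ccccc2N(Cc2ccc(Cl)cc2)S(=O)(=O)N1Cc1ccccc1`. In a functional assay on HEL cells (Homo sapiens) for inhibition (a higher number here means that more compound is tolerated, a lower number that less compound is tolerated), compound 1 gives > 200000 nM, which is a limit of the assay and not a number. Compound 1 thus stands at the limit of > 200000 nM in this assay, at which 2 of the 3 values shown sit. Compound 2 `O=C1c2ccccc2N(Cc2ccccc2Cl)S(=O)(=O)N1Cc1ccccc1Cl` gives in this assay > 200000 nM, likewise only a limit. Compound 3 `O=C1c2ccccc2N(Cc2ccccc2Cl)S(=O)(=O)N1COCc1ccccc1` gives > 50000 nM in this assay, again a limit. Compound 3 stands at the limit of > 50000 nM in this assay, at which 1 of the 3 values shown sits. Going by the values given here, the one step between measured compounds that differ in a single place, a step that the two limits leave unreadable from compound 2 to compound 3, therefore yields neither size nor direction.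

Compound 4 `O=C1c2ccccc2N(Cc2ccccc2)S(=O)(=O)N1Cc1ccccc1` differs from compound 1 by hydrogen in place of chloro on an aromatic carbon. Among the compounds with values here, no measured step bears on this change: the step from compound 2 to compound 3 is unreadable and concerns a different alteration of the core. Because compound 1 gives > 200000 nM, compound 4 is expected to stay at the same limit rather than move away from it. The step of a number no higher from compound 1 to compound 4 (the limit leaves the size open) is therefore expected to be none beyond the scatter. Compound 4 is estimated at 200000 nM in this assay, with a range from 100000 nM to 400000 nM, and the result is most likely to be reported only as a limit.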

Compound 4, half-maximal cytotoxic concentration: > 200000 nM
Compound 4: no number, only a limit; the forecaster's own chance of this, stated with the estimate: 85%; the middle value sits exactly at the limit.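

Compound 1 and compound 4 both give only a limit in this assay and not a number, so the step between them cannot be read in size or direction. With only limits among the compounds shown, it stays open whether any change to the shared core, 4-chlorobenzyl to benzyl included, alters the half-maximal cytotoxic concentration at all.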